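Chloro for Methoxy, Tried on a Second Core

The compounds below may be only part of what the source reports. "The series", "measured", "known", "first", "only" and "open" are said of these compounds alone.

Compound 1, `COc1ccccc1N1CCN(CCCn2ncc(N3CCN(C(=O)c4ccco4)CC3)c(Cl)c2=O)CC1` — in an assay on cell membranes for binding affinity to Adrenergic receptor alpha-1 (Rattus norvegicus), read by radioligand binding (on this read-out lower numbers stand for stronger inhibition and higher numbers for weaker inhibition), compound 1 gives 20.4 nM
Compound 2, `O=C(c1ccco1)N1CCN(c2cnn(CCCN3CCN(c4ccccc4Cl)CC3)c(=O)c2Cl)CC1` — compound 2 gives 3.5 nM
Compound 3, `COc1ccccc1N1CCN(CCCCCCn2nc(N3CCN(C(=O)c4ccco4)CC3)ccc2=O)CC1` — compound 3 gives 17.8 nM

Compounds 1 and 2 share one core and differ in a single spot: chloro in place of methoxy on an aromatic carbon. That exchange gave a 5.8-fold lower number from compound 1 to compound 2 (0.77 log units; beyond the scatter), a clear gain in binding by the standard of this assay.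

Compound 3 carries a different core; the difference between the two cores is not broken down here. Its number sits close to that of compound 1, and the two lie within the usual scatter of each other, so nothing separates them. Compound 2 stands apart from both.

Compound 4, `O=C(c1ccco1)N1CCN(c2ccc(=O)n(CCCCCCN3CCN(c4ccccc4Cl)CC3)n2)CC1`, has not yet been measured. Against compound 3 it shows exactly the kind of change already seen between compounds 1 and 2: chloro in place of methoxy on an aromatic carbon. The surroundings of the exchanged group read the same in both pairs, so this is the same change made on a second core.

For the measured compounds named here, the expectation is that the step from compound 3 to compound 4 will run in the same direction as the earlier one, because the only measured example of this exchange gave a 5.8-fold lower number from compound 1 to compound 2 (0.77 log units; beyond the scatter). With a single precedent and a different core, a somewhat smaller step, a 4.0-fold lower number from compound 3 to compound 4 (0.60 log units; beyond the scatter), is estimated. Compound 4 is therefore expected to land near 4.5 nM in this assay, most likely between 2 nM and 12 nM.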

Compound 4, inhibition constant: 5.9 nM
For compound 4 the middle estimate is 1.3-fold (0.12 log units) below the measured one; the range from low to high includes it.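

Replacing methoxy with chloro on compound 3, the 2-methoxyphenyl to 2-chlorophenyl change, gave a 3.0-fold lower number from compound 3 to compound 4 (0.48 log units; beyond the scatter) in this assay, so the exchange that lowered the number on the first core also lowered it on the second. The two steps run in the same direction and cannot be told apart in size, which means that the effect of this exchange carried over intact as far as this assay can resolve: the same change on two cores in this assay, a 5.8-fold lower number (0.77 log units; beyond the scatter) from compound 1 to compound 2 and a 3.0-fold lower number (0.48 log units; beyond the scatter) from compound 3 to compound 4, 1.9-fold (0.29 log units) apart, within the scatter of two such steps. For the compounds shown here, this is still only two pairs of compounds, so it supports transfer between these two cores but does not show that the exchange would behave the same way on a third core, and it does not explain why the number falls.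

The compounds shown leave open whether the gain is particular to chloro, since no other group, such as fluoro or methyl, appears in this place on the ring for comparison. Going by these compounds alone, they also leave open how much the two cores themselves contribute, since each pair compares compounds on one core and no step links one core to the other.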